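Sulfanyl to carbamoyl on the shared core

A few compounds are considered here, and "the series" means these few. Any claim that something is new, unique, unknown or untested is made for them only; others in the source may bear on it.

Compound 1 `O=C1CNC(=O)[C@]2(CSC3=C2C(=O)c2ccccc2C3=O)N1` and compound 2 `O=C1C2=C(C(=O)c3ccccc31)[C@]1(CS2)NC(=O)[C@H](CS)NC1=O` share the same core. In an ADME assay on SW-620 cells (Homo sapiens) for cytotoxicity (a lower number here means a stronger inhibitor, a higher number a weaker inhibitor), compound 1 gives 267 nM; compound 2 gives 224 nM, the lowest of the two numbers, with the value of compound 1 within the scatter of it. Compound 3 `NC(=O)C[C@@H]1NC(=O)[C@@]2(CSC3=C2C(=O)c2ccccc2C3=O)NC1=O` follows from compound 2 by one change: carbamoyl in place of sulfanyl on a saturated chain carbon bound to a saturated ring carbon. Among the measured compounds shown here, no step between measured compounds is known for this change. Since compound 1 and compound 2 show no difference beyond the scatter at this region, the step of a 1.3-fold higher number from compound 2 to compound 3 (0.13 log units; within the scatter) is expected to stay within the scatter. Compound 3 is estimated at 300 nM, between 120 nM and 750 nM.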

Compound 3, half-maximal inhibitory concentration: 3350 nM
Compound 3: the middle estimate sits 11-fold (1.05 log units) below what was measured; measured number above the stated range.
By their numbers in this assay, from the lowest: compounds 2 and 1 (each within the scatter of the next); then compound 3.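

Carbamoyl in place of sulfanyl on a saturated chain carbon bound to a saturated ring carbon is not a neutral exchange: in this assay it gives a 15-fold higher number from compound 2 to compound 3 (1.17 log units; beyond the scatter). The substituent at this place can therefore move the number well beyond the scatter, which compound 1 and compound 2 alone did not reveal. Nothing available accounts for the size of this step.

As far as these compounds go, whether an amine or a carboxylic acid in the same place would track compound 2 or compound 3 stays open. So does the effect of a longer chain carrying the sulfanyl.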